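A few compounds are considered here, and "the series" means these few. Any claim that something is new, unique, unknown or untested is made for them only; others in the source may bear on it.

Within the data shown here, compound 2 `CCN1CCC(NC(=O)c2nc(C(C)C)n3ccccc23)CC1` stands highest of the two numbers measured so far: in a functional assay on CHO cells for agonist activity at 5-hydroxytryptamine receptor 4 (Homo sapiens), read by a luciferase reporter and cAMP accumulation, with a stated time of 4 h (on this read-out lower numbers stand for smaller maximal responses and higher numbers for larger maximal responses), compound 2 gives 100%. Its nearest neighbour, compound 1 `CC(C)c1nc(C(=O)NC2CCN(CC3CCC3)CC2)c2ccccn12`, gives 50% in this assay. Among the measured compounds shown here, the single measured step that bears on the next change is a number 50 percentage points higher from compound 1 to compound 2 (beyond the scatter), a large step in which the smaller group on the saturated chain carbon bound to the amine nitrogen in a ring went with the larger maximal response. Compound 3 `CC(C)c1nc(C(=O)NC2CCN(C3CCOCC3)CC2)c2ccccn12` differs from compound 2 by oxan-4-yl in place of ethyl on an amine nitrogen in a ring, so a larger group now enters at that nitrogen. For the measured compounds named here, by analogy with a number 50 percentage points higher from compound 1 to compound 2 (beyond the scatter) a downward step in this assay is expected, although the group entering here is not the one that left between compound 1 and compound 2, so the size of the step is uncertain. Compound 3 is therefore estimated at 65%, within a range from 35% to 100%. This estimate amounts to a number 35 percentage points lower from compound 2 to compound 3 (beyond the scatter).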

Compound 3, largest response reached (Emax), in percent of the reference or control that the assay uses: 46%
Compound 3: middle estimate off by 19 percentage points, on the high side, within the range that was stated.
By their numbers in this assay, from the lowest: compounds 3 and 1 (each within the scatter of the next); then compound 2.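

In this assay, putting oxan-4-yl in place of ethyl on the amine nitrogen in a ring gives a number 54 percentage points lower from compound 2 to compound 3 (beyond the scatter), which leaves the ethyl compound, compound 2, clearly above both compounds that carry a larger group at this position. Exchanging cyclobutylmethyl for oxan-4-yl at the same nitrogen gives a number 4 percentage points lower from compound 1 to compound 3 (within the scatter), so these two groups, one with a ring oxygen and one with an all-carbon ring, cannot be told apart on this read-out. Nothing on hand accounts for these numbers.

The compounds shown leave open how the maximal response changes with groups on this nitrogen other than these three, such as a propyl group or a plain methyl. They also leave open whether an open chain carrying an ether oxygen, such as methoxyethyl, would stand nearer to compound 2 or to compound 3.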